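A few compounds are considered here, and "the series" means these few. Any claim that something is new, unique, unknown or untested is made for them only; others in the source may bear on it.

Measured so far in a functional assay on A2780 cells (Homo sapiens) for antiproliferative activity; on this read-out lower numbers stand for stronger inhibition and higher numbers for weaker inhibition:

Compound 1, `CCN1Cc2c(ccc(C)c2C)C(c2ccccc2)C1`: compound 1 gives 5300 nM.
Compound 2, `Cc1ccc2c(c1C)CN(C(C)C)CC2c1ccccc1`: compound 2 gives 6280 nM.
Compound 3, `Cc1cccc2c1CN(C(=O)N(C)C)CC2c1cccc(O)c1`: compound 3 gives 2050 nM.

Compound 1 and compound 2 differ in one place, (methyl in place of hydrogen on a saturated chain carbon bound to an amine nitrogen in a ring and a saturated chain carbon), and the step is a 1.2-fold higher number from compound 1 to compound 2 (0.07 log units; within the scatter). Compound 3 gives the lowest of the three numbers, and its gaps to compound 1 and to compound 2 are both beyond the scatter; how its core differs from the core of compound 1 is not broken down here.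

Compound 4, `CCc1cccc2c1CN(C(=O)N(C)C)CC2c1cccc(O)c1`, is not yet measured. It differs from compound 3 by methyl in place of hydrogen on a saturated chain carbon bound to an aromatic carbon. This is the same kind of change as that from compound 1 to compound 2, not the same: there the place was a saturated chain carbon bound to an amine nitrogen in a ring and a saturated chain carbon, here it is a saturated chain carbon bound to an aromatic carbon. Among the measured compounds shown here, the only precedent is a step within the scatter, so from compound 3 to compound 4 a small step, a 1.2-fold higher number from compound 3 to compound 4 (0.07 log units; within the scatter), is expected because a 1.2-fold higher number from compound 1 to compound 2 (0.07 log units; within the scatter) was small; the different place leaves the direction uncertain. Compound 4 is estimated at 2400 nM, between 1200 nM and 4800 nM.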

Compound 4, half-maximal inhibitory concentration: 186 nM
Compound 4: the middle estimate sits 13-fold (1.11 log units) above what was measured, outside the stated range (below it).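

In this assay, methyl in place of hydrogen on a saturated chain carbon bound to an aromatic carbon gives an 11-fold lower number from compound 3 to compound 4 (1.04 log units; beyond the scatter) and so turns the methyl of compound 3 into the ethyl of compound 4 with a large effect on this core. The two steps differ in both core and place, and the data do not separate these two factors, so nothing here shows which of them accounts for the gap or why it arises. The size of this change therefore does not carry from one core to the other in this series, and a single step on one core is a poor guide to the step on another: the same change on two cores in this assay, a 1.2-fold higher number (0.07 log units; within the scatter) from compound 1 to compound 2 and an 11-fold lower number (1.04 log units; beyond the scatter) from compound 3 to compound 4, 13-fold (1.12 log units) apart, beyond the scatter of two such steps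

The compounds shown leave open whether the lower number persists with a longer chain such as propyl, or with a branched or ring group such as isopropyl or cyclopropyl, at this place on the core of compound 3. They also leave open whether methyl to ethyl at a saturated chain carbon bound to an aromatic carbon gives a step of similar size on the core of compound 1.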